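The source may report more compounds than this note shows. Statements on the series, on what has been measured and on what is new or still open speak of the compounds shown alone.

Measured in a functional assay on RPMI-8226 cells (Homo sapiens) for cytotoxicity, read by MTT assay, with a stated time of 48 h; a higher number here means a weaker inhibitor, a lower number a stronger inhibitor:
- Compound 1 `ClC1=C(Cl)C(Cl)=C(Cl)C1=NN(c1ccccc1)c1ccccc1`: > 3000 nM (a limit)
- Compound 2 `Fc1cccc(NN=C2C(Cl)=C(Cl)C(Cl)=C2Cl)c1`: 500 nM
- Compound 3 `COc1cccc(NN=C2C(Cl)=C(Cl)C(Cl)=C2Cl)c1`: > 3000 nM (a limit)

Compound 3 gives no exact number and stands at the limit of > 3000 nM in this assay, at which 2 of the 3 values shown sit. Compound 4 `ClC1=C(Cl)C(Cl)=C(Cl)C1=NNc1ccccc1` differs from compound 3 by one change, hydrogen in place of methoxy on an aromatic carbon.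

Among the measured compounds shown here, one measured step bears on this change. With methoxy in place of fluoro on an aromatic carbon, the number rises an at least 6.0-fold higher number from compound 2 to compound 3 (0.77 log units; beyond the scatter), a change beyond the scatter. Removing the methoxy of compound 3 may therefore reverse much of that rise, so a lower number is expected in this assay. For the measured compounds named here, no measured compound shows how hydrogen compares with fluoro on this ring, so the size of the drop remains uncertain. The expected change is an at least 3.7-fold lower number from compound 3 to compound 4 (0.57 log units; beyond the scatter).

For compound 4, the estimated value is 800 nM, with an expected range from 200 nM to 3000 nM.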

Compound 4, half-maximal inhibitory concentration: 600 nM
Estimate against measurement, compound 4: 1.3-fold (0.12 log units) above; measured number inside the range.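

In this assay, replacing the methoxy with hydrogen gives an at least 5.0-fold lower number from compound 3 to compound 4 (0.69 log units; beyond the scatter), so at this place on the ring the weak result goes with methoxy and not with every group placed there. Hydrogen and fluoro cannot be told apart here, with a 1.2-fold higher number from compound 2 to compound 4 (0.08 log units; within the scatter), so on the evidence of these compounds the fluoro is not needed for the activity of compound 2. A second place also matters, as hydrogen in place of phenyl on the nitrogen gives an at least 5.0-fold lower number from compound 1 to compound 4 (0.69 log units; beyond the scatter), and this step and the methoxy step both start from a limit, so they give only a smallest possible size: the limit of > 3000 nM in this assay, at which 2 of the 4 values shown sit.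

As far as these compounds go, the full size of those two steps remains open. Also open, from the compounds shown here alone, is how an amine or a carboxylic acid at this ring place, or a methyl group on the nitrogen, would compare with hydrogen.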